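Swapping the Aryl Group on Compound 3

The source may hold more compounds than are shown below. What is called first, only, known or untested is meant among the compounds shown, and "the series" means these compounds.

Compound 3 `Cc1ccc(C(=O)CCc2nnc(-c3ccccc3Cl)o2)cc1` stands highest of the three compounds measured in a functional assay on the whole organism (strain Wistar) for inhibition, with Rattus norvegicus as the target, with stated times of 30 min and 3 h, at a dose of 20 mg/kg by the oral route (a higher number here means more inhibition at the dose given (going by the name of the read-out), a lower number less inhibition), where compound 3 gives 57.3%. Compound 2 `O=C(CCc1nnc(-c2ccccc2Cl)o1)c1ccccc1` gives 35.8% and compound 1 `O=C(CCc1nnc(-c2ccccc2)o1)c1ccccc1` gives 29.4%; the measured steps were a number 6.4 percentage points higher from compound 1 to compound 2 (within the scatter) and a number 21.5 percentage points higher from compound 2 to compound 3 (beyond the scatter). Compound 4 `COc1ccc(-c2nnc(CCC(=O)c3ccc(C)cc3)o2)cc1` differs from compound 3 by 4-methoxyphenyl in place of 2-chlorophenyl on an aromatic carbon. For the measured compounds named here, only the step from compound 1 to compound 2 touches the 2-chlorophenyl group, and a number 6.4 percentage points higher from compound 1 to compound 2 (within the scatter) lies within the scatter; no measured step covers the 4-methoxyphenyl group. A small fall is therefore expected, a number 7.3 percentage points lower from compound 3 to compound 4 (within the scatter), with a wide range around it. Compound 4 is estimated at 50%, between 30% and 70%.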

Compound 4, a percentage reported as inhibition, in the whole organism at one dose (the size of the read-out at that dose, not a potency): 89.5%
Compound 4: the middle estimate sits 39.5 percentage points below what was measured, outside the stated range (above it).
By their numbers in this assay, from the lowest: compounds 1 and 2 (each within the scatter of the next); then compound 3; then compound 4.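

In this assay, the aryl group on this carbon of the five-membered ring proves able to move the read-out strongly: 4-methoxyphenyl in place of 2-chlorophenyl gives a number 32.2 percentage points higher from compound 3 to compound 4 (beyond the scatter). The only earlier change on this aryl group, a number 6.4 percentage points higher from compound 1 to compound 2 (within the scatter), had shown no such reach. Nothing available explains the rise.

This exchange alters both the substituent and where it sits on the phenyl ring, so the two contributions remain unseparated. From the compounds shown here alone, whether 4-chlorophenyl, 2-methoxyphenyl or 4-aminophenyl would hold this level remains open.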